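This account rests on a few compounds, and the source may have more. Where it says the series, first, only, none or still open, it means among the compounds named here.

Measured so far:
compound 1 `CC(C)C(Nc1nnc[nH]1)c1ccc(-c2ccc3cccc(F)c3c2)[nH]c1=O` — 185 nM
compound 2 `CC(C)C(Cc1nnc[nH]1)c1ccc(-c2ccc3cccc(F)c3c2)[nH]c1=O` — 17 nM

In a functional assay on CHO cells for antagonist activity at prostaglandin E2 receptor EP3 subtype (Homo sapiens), read by cAMP accumulation (a lower number here means a stronger inhibitor, a higher number a weaker inhibitor), compound 2 gives 17 nM, the lowest of the two numbers seen so far. Its nearest neighbour is compound 1, which in this assay gives 185 nM. Among the compounds with values here, the single step measured between them, an 11-fold lower number from compound 1 to compound 2 (1.04 log units; beyond the scatter), is large and lies beyond the scatter.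

Compound 3 `CC(C)C(c1ccc(-c2ccc3cccc(F)c3c2)[nH]c1=O)N1CCCCC1=O` differs from compound 2 in one place: 2-oxopiperidin-1-yl in place of (4H-1,2,4-triazol-3-yl)methyl on a saturated chain carbon bound to an aromatic carbon and a saturated chain carbon. Within the data shown here, the one measured step bears on this only indirectly: it concerns the link between the chain carbon and the triazole ring, whereas here the ring itself leaves and a lactam enters. What that step does show is that this position answers strongly to change. Among the measured compounds shown here, with no direct precedent, the expected step in this assay is a move towards a higher number, plausibly beyond the scatter, but with wide uncertainty.

Compound 3 is therefore estimated at 60 nM, within a range of 15 nM to 300 nM. This estimate corresponds to an expected step of a 3.5-fold higher number from compound 2 to compound 3 (0.55 log units; beyond the scatter).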

Compound 3, half-maximal inhibitory concentration: 40 nM
Beside the measured number, compound 3's estimate is 1.5-fold (0.18 log units) above it; the range from low to high includes it.
By their numbers in this assay, from the lowest: compound 2; then compound 3; then compound 1.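

In this assay the (4H-1,2,4-triazol-3-yl)methyl group proves replaceable at this saturated chain carbon by a quite different one: the change to 2-oxopiperidin-1-yl, a six-membered non-aromatic ring with no hydrogen-bond donor, gives a 2.4-fold higher number from compound 2 to compound 3 (0.37 log units; beyond the scatter) and is only a modest step, though beyond the scatter. Against the amino-linked triazole, the same group gives a 4.6-fold lower number from compound 1 to compound 3 (0.67 log units; beyond the scatter) and so sets compound 3 between the other two, which shows that a nitrogen bound to this carbon does not by itself go with the highest number, since compound 3 carries a nitrogen there as well and compound 1 stands well above it. No supporting measurement bears on why the three groups fall in this order.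

The change from compound 2 to compound 3 alters the ring, its link and its hydrogen-bond count all at once, so the compounds shown cannot say which of these sets the size of the step. They also leave open how a smaller lactam such as 2-oxopyrrolidin-1-yl, an open-chain acetamide, or a carboxylic acid would fare on this carbon.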